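Thiophenylmethyl Amine Replaces Thiophenylcarbonyl Amide in a Urotensin Series

A few compounds are considered here, and "the series" means these few. Any claim that something is new, unique, unknown or untested is made for them only; others in the source may bear on it.

Compound 2 `CCN1CCN(c2cccc3c2CN([C@H](CCCNC(=O)c2cccs2)c2ccc(OC)c(OC)c2)C3=O)CC1` gives 7 nM in a functional assay on CHO-K1 cells for antagonist activity at Urotensin-2 receptor (Rattus norvegicus), read by FLIPR and calcium flux, with a stated time of 1 h (a lower number here means a stronger inhibitor, a higher number a weaker inhibitor), level with compound 1 `CCN1CCN(c2cccc3c2CN([C@H](CCCN(C)S(=O)(=O)c2cccs2)c2ccc(OC)c(OC)c2)C3=O)CC1` at 7 nM. The change no change at the digits printed from compound 1 to compound 2 (within the scatter) shows that swapping the methyl((thiophen-2-yl)sulfonyl)amino group for the ((thiophen-2-yl)carbonyl)amino group cost nothing. Compound 3 `CCN1CCN(c2cccc3c2CN([C@H](CCCNCc2cccs2)c2ccc(OC)c(OC)c2)C3=O)CC1` goes a step further: (thiophen-2-yl)methyl in place of (thiophen-2-yl)carbonyl on an amine nitrogen. Within the data shown here, no measured step removes the carbonyl in this way, so the only bearing is the tolerance seen from compound 1 to compound 2. Compound 3 is therefore expected to stay close, with a step of a 2.1-fold higher number from compound 2 to compound 3 (0.33 log units; beyond the scatter), giving an estimate of 15 nM (range 4 nM to 60 nM).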

Compound 3, half-maximal inhibitory concentration: 6 nM
For compound 3 the middle estimate is 2.5-fold (0.40 log units) above the measured one; the range from low to high includes it.
By their numbers in this assay, from the lowest: compounds 3, 1 and 2 (each within the scatter of the next).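

In this assay, the carbonyl on this amine nitrogen can be replaced: (thiophen-2-yl)methyl in place of (thiophen-2-yl)carbonyl gives a 1.2-fold lower number from compound 2 to compound 3 (0.07 log units; within the scatter) and leaves the level unchanged. The ((thiophen-2-yl)methyl)amino group also matches the methyl((thiophen-2-yl)sulfonyl)amino group, with a 1.2-fold lower number from compound 1 to compound 3 (0.07 log units; within the scatter) as the step, so carbonyl, sulfonyl and methylene links to the thiophene all sit within the scatter here. No measurement given here accounts for this tolerance.

Going by these compounds, whether a phenyl or furan ring could replace the thiophene remains open. So does the effect of a longer chain on the amine nitrogen.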